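This account rests on a few compounds, and the source may have more. Where it says the series, first, only, none or still open, it means among the compounds named here.

Three compounds share one core, a ring-fused amine carrying a thiourea linked to an aryl carbonyl, with a five-carbon chain ending in a chlorophenoxy group. Compound 1 is `Cc1ccc(C(=O)NC(=S)N2CCc3c(OCCCCCOc4ccc(Cl)cc4)cccc32)cc1`, compound 2 is `CC(C)(C)c1ccc(C(=O)NC(=S)N2CCc3c(OCCCCCOc4ccc(Cl)cc4)cccc32)cc1`, and compound 3 is `O=C(NC(=S)N1CCc2c(OCCCCCOc3ccc(Cl)cc3)cccc21)c1ccc2ccccc2c1`. All three were tested in an ADME assay on Huh-7 cells (Homo sapiens) for cytotoxicity; a lower number here means that less compound is tolerated, a higher number that more compound is tolerated. In this assay compound 1 reaches only the limit of the measurement, > 50000 nM. Compound 2 likewise reaches only that limit, > 50000 nM. Compound 3 also reaches only the limit, > 50000 nM. The steps between them cannot be sized: a step that the two limits leave unreadable from compound 1 to compound 2, a step that the two limits leave unreadable from compound 1 to compound 3 and a step that the two limits leave unreadable from compound 2 to compound 3. All that can be said is the limit of > 50000 nM in this assay, at which 3 of the 3 values shown sit, so compound 3 stands where its two neighbours stand, at the edge of what the assay can report.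

Compound 4 is `O=C(NC(=S)N1CCc2c(OCCCCCOc3ccc(Cl)cc3)cccc21)c1ccoc1`. It differs from compound 3 in one place: furan-3-yl in place of naphthalen-2-yl on a carbonyl carbon. Going by the values given here, none of the measured steps is readable, so no direction can be taken from them; they only show that changes on this carbonyl position have so far left every value at the limit. The step from compound 3 to compound 4 is therefore expected to be a step that the limit leaves unreadable from compound 3 to compound 4. Compound 4 is expected to give 60000 nM, within a range from 25000 nM to 150000 nM.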

Compound 4, half-maximal cytotoxic concentration: 20100 nM
Compound 4: middle estimate off by 3.0-fold (0.47 log units), on the high side; the measured number lies below the stated range.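

Going by these compounds alone, the furan-3-yl group is the first on this carbonyl carbon to bring the read-out of this assay within the measurable range, meaning that cells tolerate less of this compound: in place of naphthalen-2-yl it gives an at least 2.4-fold lower number from compound 3 to compound 4 (0.39 log units; beyond the scatter). The same change from the two substituted phenyl groups shows the same drop, with 4-(tert-butyl)phenyl giving an at least 2.4-fold lower number from compound 2 to compound 4 (0.39 log units; beyond the scatter) and 4-methylphenyl giving an at least 2.4-fold lower number from compound 1 to compound 4 (0.39 log units; beyond the scatter). These steps give only the smallest possible size of each drop, and the steps among the three earlier compounds cannot be read at all, because those compounds stop at the same limit: the limit of > 50000 nM in this assay, at which 3 of the 4 values shown sit.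

With furan-3-yl as the only group here that gives a measured number, the compounds shown cannot separate the effect of swapping in a smaller ring from that of bringing in its ring oxygen. Going by these compounds, a plain phenyl, a thiophen-3-yl or a pyridin-3-yl on the same carbonyl carbon would help to tell these apart, and it also remains open whether a shorter chain in place of the five-carbon chain would move the number.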